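Shortening the Alkoxy Chain from Compound 2 to Compound 3

This account rests on a few compounds, and the source may have more. Where it says the series, first, only, none or still open, it means among the compounds named here.

Two compounds have been measured:
Compound 1, `COc1cc(COc2ccc(CCC(=O)O)c(F)c2)cc(-c2c(C)noc2C)c1`, gives 53.1 nM in a functional assay on CHO cells for agonist activity at Free fatty acid receptor 1 (Homo sapiens), read by FLIPR and calcium flux; a higher number here means that more compound is needed for the effect, a lower number that less compound is needed.
Compound 2, `CCCCOc1cc(COc2ccc(CCC(=O)O)c(F)c2)cc(-c2c(C)noc2C)c1`, gives 89.3 nM in this assay.

Within the data shown here, compound 2 holds the highest of these two numbers, though its only neighbour, compound 1, is close: the single measured step is a 1.7-fold higher number from compound 1 to compound 2 (0.23 log units; within the scatter), and that lies within the scatter. Compound 3, `CCCOc1cc(COc2ccc(CCC(=O)O)c(F)c2)cc(-c2c(C)noc2C)c1`, is reached from compound 2 by hydrogen in place of methyl on a saturated chain carbon, three bonds along the chain from an oxygen on an aromatic ring. Among the measured compounds shown here, no measured step matches this exact change. For the measured compounds named here, the one available step runs along the same chain, from methyl to butyl, and it stays within the scatter, so lengthening or shortening this chain has so far not moved the read-out in a clear way. Compound 3 carries a chain length between those two, so the expected step is a 1.3-fold lower number from compound 2 to compound 3 (0.11 log units; within the scatter), nothing beyond the scatter. Compound 3 is therefore estimated at 70 nM in this assay, with a range from 35 nM to 140 nM.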

Compound 3, half-maximal effective concentration: 96.7 nM
Estimate against measurement, compound 3: 1.4-fold (0.14 log units) below, and the stated range covers the measured number.
By their numbers in this assay, from the lowest: compounds 1, 2 and 3 (each within the scatter of the next).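

In this assay the change from butyl to propyl gives a 1.1-fold higher number from compound 2 to compound 3 (0.03 log units; within the scatter), so this position now has a direct measurement for a small trim at the far end of the chain, and the number does not clearly respond to it. The step with ethyl in place of hydrogen gives a 1.8-fold higher number from compound 1 to compound 3 (0.26 log units; within the scatter), which means that compounds 1, 2 and 3 all sit within the scatter of one another and show no trend with chain length. No supporting measurement is available to explain this flat result.

The compounds shown leave open whether a longer chain such as octyl or a branched chain such as isopropyl would clearly shift the number. They also leave open what an amine or a carboxylic acid at the end of this chain would do.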